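Efficacy of a pyridine N-oxide anilide after the aryl swap

The compounds below may be only part of what the source reports. "The series", "measured", "known", "first", "only" and "open" are said of these compounds alone.

Compound 2 `O=C(CN1CCC(c2cccc[n+]2[O-])CC1)Nc1ccc(F)cc1F` gives 74% in a functional assay on HEK293 cells for agonist activity at D(4) dopamine receptor (Homo sapiens), read by FLIPR (on this read-out higher numbers stand for larger maximal responses and lower numbers for smaller maximal responses), the highest of the three numbers measured; compound 3 `Cc1cccc(NC(=O)CN2CCC(c3cccc(F)c3)CC2)c1` gives 40% and compound 1 `Cc1cccc(NC(=O)CN2CCC(c3ccccc3)CC2)c1` gives 37%, both well beyond the scatter below compound 2. Compound 4 `O=C(CN1CCC(c2cccc[n+]2[O-])CC1)Nc1cccc(F)c1` differs from compound 2 in a single place: 3-fluorophenyl in place of 2,4-difluorophenyl on an amide-type nitrogen. For the measured compounds named here, the only step measured between two compounds that differ in one place is on the other ring of the shared core, fluoro in place of hydrogen on an aromatic carbon, which gave a number 3 percentage points higher from compound 1 to compound 3 (within the scatter) in this assay; no measured step touches the aryl on the amide-type nitrogen, so it bears on the present change only loosely. Compound 4 keeps the part of compound 2 that sets it apart from compounds 1 and 3, so its maximal response is expected to remain nearer compound 2 than compound 1, with a modest loss of the kind an aryl change can bring, an expected step of a number 12 percentage points lower from compound 2 to compound 4 (beyond the scatter). Compound 4 is therefore estimated at 62%, within 42% to 82%.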

Compound 4, largest response reached (reported as efficacy), in percent of the reference or control that the assay uses: 70%
For compound 4 the middle estimate is 8 percentage points below the measured one; the measured number falls inside the stated range.
By their numbers in this assay, from the lowest: compounds 1 and 3 (each within the scatter of the next); then compounds 4 and 2 (each within the scatter of the next).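

Across this assay, the step of a number 4 percentage points lower from compound 2 to compound 4 (within the scatter) gives the first reading at the aryl on the amide-type nitrogen, where the earlier step touched only the other ring of the shared core. For this pair, 3-fluorophenyl in place of 2,4-difluorophenyl leaves the maximal response within the scatter, so the change to this aryl does not separate the two compounds on this read-out. No measured evidence bearing on this result is available to explain it.

As far as these compounds go, what a 3-methoxyphenyl or a 3-chlorophenyl on that nitrogen would give remains open, as does the response with an unsubstituted phenyl there. Compounds 2 and 4 also differ from compounds 1 and 3 in more than one place, so the compounds shown do not tell which difference goes with the gap in their numbers.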